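Acetyl for methoxyethyl on the aryl ring of compound 2

The source may hold more compounds than are shown below. What is called first, only, known or untested is meant among the compounds shown, and "the series" means these compounds.

Measured compounds and values:
- compound 1, `CCCC(C)n1c(CC)nc2c(-c3ccc(OC)cc3C(F)(F)F)ccnc21`: 0.74 nM
- compound 2, `CCCC(C)n1c(CC)nc2c(-c3ccc(C(C)OC)cc3Cl)ccnc21`: 3.5 nM
- compound 3, `CCCC(C)n1c(CC)nc2c(-c3ccc(S(C)(=O)=O)cc3C(F)(F)F)ccnc21`: 6.8 nM

Three compounds share one core and differ only on the pendant aryl ring. In an assay for binding affinity to Corticotropin releasing factor receptor (Rattus norvegicus) (a higher number here means a weaker inhibitor, a lower number a stronger inhibitor), compound 1 gives 0.74 nM, compound 3 gives 6.8 nM and compound 2 gives 3.5 nM. Compound 2 stands second highest of the three numbers; its nearest neighbour is compound 3, within the scatter, while the gap to compound 1 lies beyond the scatter. Among the measured compounds shown here, the only single-point step among the measured compounds is a 9.2-fold higher number from compound 1 to compound 3 (0.96 log units; beyond the scatter).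

Compound 4, `CCCC(C)n1c(CC)nc2c(-c3ccc(C(C)=O)cc3Cl)ccnc21`, is not yet measured. It differs from compound 2 by acetyl in place of 1-methoxyethyl on an aromatic carbon, in words: acetyl in place of 1-methoxyethyl on an aromatic carbon. For the measured compounds named here, no measured step replaces one group at this place by another of this kind; the step from compound 1 to compound 3 concerns a different pair of groups and serves only as a rough guide to how much such a swap can move this assay. Going by the values given here, with no closer precedent, compound 4 is expected to stay near compound 2, with a step of a 1.3-fold higher number from compound 2 to compound 4 (0.11 log units; within the scatter) that may well fall within the scatter. Compound 4 is therefore estimated at 4.5 nM, with a range from 1.5 nM to 14 nM.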

Compound 4, inhibition constant: 1 nM
Beside the measured number, compound 4's estimate is 4.5-fold (0.65 log units) above it; the whole stated range lies above it.
By their numbers in this assay, from the lowest: compounds 1 and 4 (each within the scatter of the next); then compounds 2 and 3 (each within the scatter of the next).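

In this assay, acetyl in place of 1-methoxyethyl gives a 3.5-fold lower number from compound 2 to compound 4 (0.54 log units; beyond the scatter), so on the chloro-bearing aryl ring this aromatic carbon responds to the group it carries, which the earlier compounds had shown only on the trifluoromethyl-bearing ring, with a 9.2-fold higher number from compound 1 to compound 3 (0.96 log units; beyond the scatter). The step lies beyond the scatter even though the entering group differs modestly from the leaving one, with 3 heavy atoms against 4, a double bond outside aromatic rings and the same count of hydrogen-bond acceptors. No measurement here accounts for the shift.

On these data alone, whether it follows the carbonyl or the shorter group stays open, and a comparison of acetyl with 1-hydroxyethyl or an amide at this carbon would bear on that. Also open, as far as these compounds go, is whether acetyl would give a similar step on the trifluoromethyl-bearing ring.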